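A few compounds are considered here, and "the series" means these few. Any claim that something is new, unique, unknown or untested is made for them only; others in the source may bear on it.

Working notes on the series. In a physicochemical assay for solubility, in phosphate buffer, measured as kinetic solubility, with a stated time of 1 h, at pH 7.4 (on this read-out higher numbers stand for higher solubility and lower numbers for lower solubility), compound 1 `COc1cccc(NC(=O)COc2cc(C)nc3ccc(OC)cc23)c1` gives 35000 nM, and compound 2 `COc1ccc2nc(C)cc(OCC(=O)Nc3cc(C)ccc3OC)c2c1` gives 9500 nM. Going by the values given here, compound 2 stands lowest of the two numbers so far; the nearest is compound 1, and the one measured step between them, a 3.7-fold lower number from compound 1 to compound 2 (0.57 log units; beyond the scatter), changes the aryl on the amide-type nitrogen.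

Compound 3 `COc1ccc2nc(C)cc(OCC(=O)Nc3cc(C)c(F)c(C)c3)c2c1` is the next step from compound 2: 4-fluoro-3,5-dimethylphenyl in place of 2-methoxy-5-methylphenyl on an amide-type nitrogen. Among the compounds with values here, the only measured step that touches this position is the step from compound 1 to compound 2, a modest move in this assay, and it swaps one aryl for another on the same nitrogen. Within the data shown here, no measured pair exchanges a 2-methoxy-5-methylphenyl for a 4-fluoro-3,5-dimethylphenyl, so the direction of the new step is not fixed by the data. Given that the earlier aryl change produced only a modest shift, the step of a 1.6-fold lower number from compound 2 to compound 3 (0.20 log units; within the scatter) is expected to be of similar or smaller size, most likely a small decrease or none beyond the scatter. For compound 3 the estimate in this assay is 6000 nM, with a range of 2000 nM to 18000 nM.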

Compound 3, solubility: 31500 nM
Estimate against measurement, compound 3: 5.3-fold (0.72 log units) below; the measured number lies above the stated range.
By their numbers in this assay, from the lowest: compound 2; then compounds 3 and 1 (each within the scatter of the next).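

In this assay, going by these compounds alone, this aryl position on the amide-type nitrogen now moves in both directions: 4-fluoro-3,5-dimethylphenyl in place of 2-methoxy-5-methylphenyl gives a 3.3-fold higher number from compound 2 to compound 3 (0.52 log units; beyond the scatter), opposite in sign to the only earlier step. Set against 3-methoxyphenyl, the same group gives a 1.1-fold lower number from compound 1 to compound 3 (0.05 log units; within the scatter), so compound 2 alone stands apart among the three, and a methoxy group on the aryl does not by itself go with the low number, as compound 1 carries one and compound 3 carries none. No measurement shown gives a reason for these differences.

The compounds shown leave open whether the low number of compound 2 follows the 2-methoxy-5-methylphenyl as a whole or only one of its two substituents, and the shared core stays the same throughout, so nothing here speaks to changes there. Also open is how this position reads with an amine or a carboxylic acid on the aryl, since the three aryl groups shown carry only methoxy, methyl and fluoro substituents.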